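Oxolane amide to methoxypyrrolidine amide: expecting a gain

This account rests on a few compounds, and the source may have more. Where it says the series, first, only, none or still open, it means among the compounds named here.

Three measured compounds share one core and differ only in the group on the carbonyl carbon. Compound 1 `CCN(CC)S(=O)(=O)c1ccc(S(=O)(=O)N2CCC[C@@H](C(=O)N3CCC(OC)CC3)C2)cc1` gives 140 nM in a functional assay on MIA PaCa-2 cells (Homo sapiens) for inhibition, read by MTT assay, with a stated time of 7 days; a lower number here means a stronger inhibitor, a higher number a weaker inhibitor. Compound 2 `CCN(CC)S(=O)(=O)c1ccc(S(=O)(=O)N2CCC[C@@H](C(=O)NC3CCOCC3)C2)cc1` gives 3770 nM in this assay, and compound 3 `CCN(CC)S(=O)(=O)c1ccc(S(=O)(=O)N2CCC[C@@H](C(=O)N[C@@H]3CCOC3)C2)cc1` gives 750 nM, the second highest number of the three. Compound 4 `CCN(CC)S(=O)(=O)c1ccc(S(=O)(=O)N2CCC[C@@H](C(=O)N3CC[C@H](OC)C3)C2)cc1` carries the change (3-methoxypyrrolidin-1-yl in place of (oxolan-3-yl)amino on a carbonyl carbon). The closest comparison is the step of a 27-fold higher number from compound 1 to compound 2 (1.43 log units; beyond the scatter), where the same kind of exchange, run in the opposite direction, raised the number by a large amount; the step of a 5.4-fold higher number from compound 1 to compound 3 (0.73 log units; beyond the scatter) shows that the amide of compound 3 already stands nearer to compound 1. A step down is therefore expected, a 6.3-fold lower number from compound 3 to compound 4 (0.80 log units; beyond the scatter). Compound 4 is estimated at 120 nM, with a range from 40 nM to 400 nM.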

Compound 4, half-maximal inhibitory concentration: 2460 nM
Compound 4: middle estimate off by 21-fold (1.31 log units), on the low side, outside the stated range (above it).
By their numbers in this assay, from the lowest: compound 1; then compound 3; then compounds 4 and 2 (each within the scatter of the next).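

Dropping the hydrogen-bond donor on the amide nitrogen does not by itself give a lower number in this assay (a 3.3-fold higher number from compound 3 to compound 4 (0.52 log units; beyond the scatter)). The gain seen with 4-methoxypiperidin-1-yl does not carry over to 3-methoxypyrrolidin-1-yl (an 18-fold higher number from compound 1 to compound 4 (1.24 log units; beyond the scatter)), and this group shows no readable difference from (oxan-4-yl)amino (a 1.5-fold lower number from compound 2 to compound 4 (0.19 log units; within the scatter)).

From the compounds shown here alone, whether 4-ethoxypiperidin-1-yl, with its longer ethoxy chain, would hold the number of compound 1 stays open. Nothing given here accounts for these steps.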